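The source may hold more compounds than are shown below. What is called first, only, known or untested is meant among the compounds shown, and "the series" means these compounds.

Compound 1 `O=c1c2ccccc2[se]n1-c1nnc(-c2cccc([N+](=O)[O-])c2)s1` is one of three compounds sharing a single core and differing only in the group on the pendant ring. In a functional assay on MCF7 cells (Homo sapiens) for antiproliferative activity, read by CCK-8 assay, with a stated time of 48 h (on this read-out higher numbers stand for weaker inhibition and lower numbers for stronger inhibition), compound 1 gives 29200 nM, the highest of the three numbers. Compound 2 `O=c1c2ccccc2[se]n1-c1nnc(-c2ccc(Cl)cc2)s1` gives 19500 nM in this assay, a value within the scatter of compound 1. Compound 3 `COc1ccc(-c2nnc(-n3[se]c4ccccc4c3=O)s2)cc1` gives 10000 nM, and the gap from compound 1 to compound 3 lies beyond the scatter. For the measured compounds named here, the only step between two measured compounds that differ in one place is a 2.0-fold lower number from compound 2 to compound 3 (0.29 log units; within the scatter).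

Compound 4 `O=c1c2ccccc2[se]n1-c1nnc(-c2cc([N+](=O)[O-])cc([N+](=O)[O-])c2)s1` differs from compound 1 by nitro in place of hydrogen on an aromatic carbon. Going by the values given here, no measured step adds a nitro group to a ring that already carries one; the methoxy-for-chloro step stays within the scatter and does not speak to this change. The three values together show only modest spread across the substituents tried, so compound 1 is the best anchor. Compound 4 is therefore expected to show a 1.0-fold higher number from compound 1 to compound 4 (0.01 log units; within the scatter), with an estimate of 30000 nM, between 12000 nM and 75000 nM.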

Compound 4, half-maximal inhibitory concentration: 37800 nM
Beside the measured number, compound 4's estimate is 1.3-fold (0.10 log units) below it; the range from low to high includes it.
By their numbers in this assay, from the lowest: compounds 3, 2, 1 and 4 (each within the scatter of the next, the first and the last beyond it).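

Replacing hydrogen with nitro on an aromatic carbon of the pendant ring, meta to the nitro group already present, gives a 1.3-fold higher number from compound 1 to compound 4 (0.11 log units; within the scatter) in this assay. Compound 4 is the first compound shown with two groups on this ring, and it shows that a second nitro group at this position produces no change that can be told from the scatter. Nothing shown explains this result.

The compounds shown leave open whether an amine or a carboxylic acid at this same position, meta to the nitro group, would also leave the number within the scatter of compound 1. They also leave open whether a methyl group or a longer chain there would give a step beyond the scatter.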